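The compounds below may be only part of what the source reports. "The series", "measured", "known", "first", "only" and "open" are said of these compounds alone.

Compound 1 `COc1ccc(Cn2cc3cc(C(=N)Nc4ccc(N5CCN(C)CC5)cc4)ncc3n2)cc1`: 8000 nM
Compound 2 `COc1ccc(Cn2cc3cc(C(=N)Nc4cccc(C(F)(F)F)c4)ncc3n2)cc1`: 15500 nM
Compound 3 `Cn1cc2cc(C(=N)Nc3ccccc3)ncc2n1`: > 50000 nM

These figures come from a functional assay on MDA-MB-231 cells (Homo sapiens) for cytotoxicity, read by MTT assay, with a stated time of 72 h; a lower number here means a stronger inhibitor, a higher number a weaker inhibitor. Compound 3 stands at > 50000 nM, which is a limit of this assay and not a number. Among the compounds shown, the record therefore holds (the limit of > 50000 nM in this assay, at which 1 of the 3 values shown sits).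

The next compound is compound 4 `COc1ccc(Cn2cc3cc(C(=N)Nc4ccccc4)ncc3n2)cc1`, which differs from compound 3 by a single change: 4-methoxyphenyl in place of hydrogen on a saturated chain carbon bound to an aromatic nitrogen. Read one bond further out, methyl gives way to 4-methoxybenzyl. Going by the values given here, no measured pair differing in one place is available to size this change directly. Compound 1 and compound 2 also carry 4-methoxybenzyl, though each has a different group on the other side of the shared core. In this assay compound 1 gives 8000 nM and compound 2 gives 15500 nM. On that basis, a moderate move toward a lower number, meaning a stronger inhibitor, is expected, and the estimated step is an at least 2.5-fold lower number from compound 3 to compound 4 (0.39 log units; beyond the scatter). For compound 4 the expected value is 20000 nM, with an estimated range of 8000 nM to 50000 nM.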

Compound 4, half-maximal inhibitory concentration: 1520 nM
Estimate against measurement, compound 4: 13-fold (1.12 log units) above, outside the stated range (below it).
By their numbers in this assay, from the lowest: compound 4; then compounds 1 and 2 (each within the scatter of the next). At a limit, above all of these: compound 3.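

In this assay, going by these compounds alone, the change of methyl to 4-methoxybenzyl brings an at least 32-fold lower number from compound 3 to compound 4 (1.51 log units; beyond the scatter), which gives the first sizing of a change at this position. Compound 3 stands at a limit of the assay and not a number, so this step has only a lower bound: the limit of > 50000 nM in this assay, at which 1 of the 4 values shown sits. With 4-methoxybenzyl held in place, the substituent on the other aromatic ring also counts, as hydrogen in place of trifluoromethyl gives a 10-fold lower number from compound 2 to compound 4 (1.01 log units; beyond the scatter) and hydrogen in place of 4-methylpiperazin-1-yl gives a 5.3-fold lower number from compound 1 to compound 4 (0.72 log units; beyond the scatter).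

The compounds shown leave open whether the methoxy group contributes to the step or whether a plain benzyl or a longer chain such as phenethyl would do the same. They also leave open how a small group such as fluorine or an amine on that aromatic carbon would compare with hydrogen.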